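The source may hold more compounds than are shown below. What is called first, only, known or untested is meant among the compounds shown, and "the series" means these compounds.

Working notes on the chalcone series in a functional assay on A549 cells (Homo sapiens) for inhibition, read by MTT assay, with a stated time of 48 h, tested at 10 uM; a lower number here means less inhibition of growth, a higher number more inhibition of growth at the concentration tested.

Compound 1 `COc1ccc(C(=O)/C=C/c2ccc(OCc3cn(Cc4ccccc4)nn3)cc2)cc1` carries a methoxy on the carbonyl-bearing ring; in this assay compound 1 gives 44%. Compound 2 `COc1ccc(C(=O)/C=C/c2ccc(OCc3cn(Cc4cccc(Br)c4)nn3)cc2)cc1` differs from compound 1 by the change (bromo in place of hydrogen on an aromatic carbon), placed meta to a large group, and in this assay compound 2 gives 47%. The step of a number 3 percentage points higher from compound 1 to compound 2 (within the scatter) shows that this change left the growth inhibition essentially where it was.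

Compound 3 `O=C(/C=C/c1ccc(OCc2cn(Cc3ccccc3)nn2)cc1)c1ccc([N+](=O)[O-])cc1` differs from compound 1 in its core by nitro in place of methoxy on an aromatic carbon. In this assay compound 3 gives "not active" (no number reported), so no single number exists for it.

Compound 4 `O=C(/C=C/c1ccc(OCc2cn(Cc3ccccc3Br)nn2)cc1)c1ccc([N+](=O)[O-])cc1`, not yet measured, differs from compound 3 by bromo in place of hydrogen on an aromatic carbon, the same kind of change as from compound 1 to compound 2 but with the bromo placed ortho to a large group rather than meta. The earlier step of a number 3 percentage points higher from compound 1 to compound 2 (within the scatter) being within the scatter, a step of similar small size is expected from compound 3 to compound 4 in this assay, starting from the inactive compound 3. Compound 4 is therefore expected to give about 10% in this assay, with a range from 0% to 30% estimated.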

Compound 4, percent growth inhibition at one concentration: 42%
Compound 4: the middle estimate sits 32 percentage points below what was measured; the whole stated range lies below it.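

Within the data shown here, no step from compound 3 to compound 4 can be read in this assay, as compound 3 gives "not active" (no number reported) and compound 4 gives 42%. The compounds shown leave open how benzyl to 2-bromobenzyl alters growth inhibition on this core when both partners carry a number. No supporting data bear on this result.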